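Butoxy for ethyl in a series stuck at a limit

A few compounds are considered here, and "the series" means these few. Any claim that something is new, unique, unknown or untested is made for them only; others in the source may bear on it.

Compound 1 `CC1CCN(C2CCN(S(=O)(=O)c3ccc(C#N)cc3)CC2)CC1`: > 5000 nM (a limit)
Compound 2 `CC1CCN(C2CCN(S(=O)(=O)c3ccc(-c4ccccc4)cc3)CC2)CC1`: > 5000 nM (a limit)
Compound 3 `CCc1ccc(S(=O)(=O)N2CCC(N3CCC(C)CC3)CC2)cc1`: > 5000 nM (a limit)

Compound 3 gives only a limit in an ADME assay on HCT-116 cells (Homo sapiens) for cytotoxicity, read by CellTiter-Glo, with a stated time of 72 h (on this read-out lower numbers stand for stronger inhibition and higher numbers for weaker inhibition), > 5000 nM, and not an exact number. The whole set shares this position: the limit of > 5000 nM in this assay, at which 3 of the 3 values shown sit.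

Compound 4 `CCCCOc1ccc(S(=O)(=O)N2CCC(N3CCC(C)CC3)CC2)cc1` carries butoxy in place of ethyl on an aromatic carbon, para to a large group: butoxy in place of ethyl on an aromatic carbon.

Three measured steps also swap one group for another on an aromatic carbon: a step that the two limits leave unreadable from compound 1 to compound 2, a step that the two limits leave unreadable from compound 1 to compound 3 and a step that the two limits leave unreadable from compound 2 to compound 3. None of them has a readable size, so they offer no direction for the new swap. No step beyond the usual scatter can be predicted from them, and compound 4 is expected to stay close to the same limit.

The estimated step is a step that the limit leaves unreadable from compound 3 to compound 4.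

For compound 4 the expected value is 7000 nM, with an estimated range of 3000 nM to 20000 nM.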

Compound 4, half-maximal inhibitory concentration: > 5000 nM
Compound 4: a limit, no number; the forecaster's own chance of this, stated with the estimate: 80%; the middle value lies beyond the limit too.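

Among the compounds shown here, compound 4 also gives only a limit, > 5000 nM, so no step between it and compound 1, compound 2 or compound 3 can be read. The compounds shown leave open whether any group at this place gives an exact number, with all of them sharing one position: the limit of > 5000 nM in this assay, at which 4 of the 4 values shown sit.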